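Swapping an Acetamido Arm for Phenyl at the Hydrazone Carbon

This account rests on a few compounds, and the source may have more. Where it says the series, first, only, none or still open, it means among the compounds named here.

Three compounds share one core and differ only in the group on the carbon double-bonded to nitrogen. Compound 1 `CCCCC/C=C/C=C/C=N/Nc1nc(N)c2ncn([C@@H]3O[C@H](CO)[C@@H](O)[C@H]3O)c2n1` carries an open chain; in an assay on CHO-K1 cells for displacement of a labelled ligand from adenosine receptor A1 (Homo sapiens), read by scintillation counting, with a stated time of 60 min (a lower number here means a stronger inhibitor, a higher number a weaker inhibitor), compound 1 gives 2 nM. Compound 3 `Nc1nc(N/N=C/c2ccc(Br)cn2)nc2c1ncn2[C@@H]1O[C@H](CO)[C@@H](O)[C@H]1O` carries 5-bromopyridin-2-yl and gives 4.7 nM, which is a 2.4-fold higher number from compound 1 to compound 3 (0.37 log units; beyond the scatter). Compound 2 `CC(=O)Nc1ccc(/C=N/Nc2nc(N)c3ncn([C@@H]4O[C@H](CO)[C@@H](O)[C@H]4O)c3n2)cc1` carries 4-acetamidophenyl. For compound 2 this assay reports only a limit, > 10000 nM, so compound 2 stands at the limit of > 10000 nM in this assay, at which 1 of the 3 values shown sits. The steps framing it are an at least 5000-fold higher number from compound 1 to compound 2 (3.69 log units; beyond the scatter) and an at least 2100-fold lower number from compound 2 to compound 3 (3.32 log units; beyond the scatter). Compound 4 `Nc1nc(N/N=C/c2ccc(-c3ccccc3)cc2)nc2c1ncn2[C@@H]1O[C@H](CO)[C@@H](O)[C@H]1O` differs from compound 2 by phenyl in place of acetamido on an aromatic carbon. Going by the values given here, the acetamido is the one feature found in compound 2 alone, and removing it is expected to give a large step to a lower number, an at least 100-fold lower number from compound 2 to compound 4 (2.00 log units; beyond the scatter). Compound 4 is estimated at 100 nM, within 5 nM to 2000 nM.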

Compound 4, inhibition constant: 7860 nM
Compound 4: the middle estimate sits 79-fold (1.90 log units) below what was measured; the measured number lies above the stated range.
By their numbers in this assay, from the lowest: compound 1; then compound 3; then compound 4. At a limit, above all of these: compound 2.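

In this assay, phenyl in place of acetamido on this aromatic carbon gives an at least 1.2-fold lower number from compound 2 to compound 4 (0.10 log units; that floor lies within the scatter). Removing acetamido therefore does not by itself bring the number close to those of compound 1 and compound 3, so acetamido alone cannot be held responsible for the weak result of compound 2. Compound 2 is known only as a limit: the limit of > 10000 nM in this assay, at which 1 of the 4 values shown sits.

Going by these compounds, the true size of this step remains open. So does whether a smaller group at this place, such as an amine or a carboxylic acid, would give a lower number.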